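The compounds below may be only part of what the source reports. "The series", "measured", "known", "first", "only" and "open" are said of these compounds alone.

Compound 2, `Cc1cn2c(/C=N/NC(=N)N)c(-c3cccnc3)nc2s1`, is one of two members of a small series tested in a functional assay (Homo sapiens) for antiproliferative activity; a lower number here means a stronger inhibitor of growth, a higher number a weaker inhibitor of growth. In this assay compound 2 gives 25700 nM, the higher of the two numbers; compound 1, `N=C(N)N/N=C/c1c(-c2ccncc2)nc2sc(Cl)cn12`, gives 13800 nM, and the gap between the two lies within the scatter of this kind of measurement. Compound 3, `N=C(N)N/N=C/c1c(-c2cccnc2)nc2sc(Cl)cn12`, has not yet been measured. It differs from compound 2 by a single change: chloro in place of methyl on an aromatic carbon. Among the compounds with values here, no measured pair shows what this change does here, so the expected step of a 1.4-fold lower number from compound 2 to compound 3 (0.15 log units; within the scatter) is small, likely none beyond the scatter. Compound 3 is therefore expected to give 18000 nM, within a range from 7000 nM to 45000 nM.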

Compound 3, concentration for total growth inhibition: 36300 nM
Beside the measured number, compound 3's estimate is 2.0-fold (0.30 log units) below it; the range from low to high includes it.
By their numbers in this assay, from the lowest: compounds 1, 2 and 3 (each within the scatter of the next, the first and the last beyond it).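

In this assay, chloro in place of methyl on the carbon next to the ring sulfur gives a 1.4-fold higher number from compound 2 to compound 3 (0.15 log units; within the scatter), so this swap has no effect that can be told from the scatter. With chloro kept, pyridin-3-yl in place of pyridin-4-yl gives a 2.6-fold higher number from compound 1 to compound 3 (0.42 log units; beyond the scatter), a modest step and the only one here beyond the scatter. Nothing measured here explains either step. From the compounds shown here alone, whether an amine or an ethyl chain on that same carbon would shift the number stays open, as does how a phenyl ring would compare with either pyridinyl group.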